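The source may report more compounds than this note shows. Statements on the series, on what has been measured and on what is new or still open speak of the compounds shown alone.

Values in a functional assay on KG-1 cells (Homo sapiens) for antiproliferative activity, read by CCK-8 assay, with a stated time of 72 h; a lower number here means a stronger inhibitor, a higher number a weaker inhibitor:
- compound 1 `C=CC(=O)Nc1ccc(-n2nc3c(=O)[nH]nc(N)c3c2-c2oc3ccc(Cl)cc3c2C)cc1`: < 0.3 nM, a limit
- compound 2 `C=CC(=O)Nc1ccc(-n2nc3c(=O)[nH]nc(N)c3c2-c2oc3ccc(C)cc3c2C)cc1`: < 0.3 nM, a limit
- compound 3 `Cc1c(-c2c3c(N)n[nH]c(=O)c3nn2-c2ccc(NC(=O)/C=C/CN(C)C)cc2)oc2ccc(Cl)cc12`: 3.7 nM

Within the data shown here, compound 3 holds the only true number so far, 3.7 nM. Compounds 1 and 2 each rest at the limit of < 0.3 nM in this assay, at which 2 of the 3 values shown sit.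

Compound 4 `Cc1ccc2oc(-c3c4c(N)n[nH]c(=O)c4nn3-c3ccc(NC(=O)/C=C/CN(C)C)cc3)c(C)c2c1` keeps all of compound 3 except one group, on an aromatic carbon of a six-membered aromatic ring of carbon only: methyl in place of chloro on an aromatic carbon. The same swap of methyl in place of chloro has been measured once, and it tells little: the result is a step that the two limits leave unreadable from compound 1 to compound 2. Both ends of that step are limits, so it gives neither a size nor a direction.

The other measured step, an at least 12-fold higher number from compound 1 to compound 3 (1.09 log units; beyond the scatter), is large, but it is a different change: 3-(dimethylamino)prop-1-en-1-yl in place of vinyl on a carbonyl carbon. Compound 4 keeps the group that compound 3 carries, so a readable number is expected rather than a limit. With no measured size for the swap, no shift beyond the scatter is expected in this assay.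

The expected change is a 1.1-fold lower number from compound 3 to compound 4 (0.02 log units; within the scatter). Compound 4 is estimated at 3.5 nM, with an expected range from 1.2 nM to 10 nM.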

Compound 4, half-maximal inhibitory concentration: < 0.3 nM
Compound 4: a limit, no number; the forecaster's own chance of this, stated with the estimate: 3%; at least 11-fold (1.06 log units) between middle value and limit.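

In this assay, the swap of methyl in place of chloro on this aromatic carbon, which gave neither size nor direction in the earlier pair, can now be read: the step is an at least 12-fold lower number from compound 3 to compound 4 (1.09 log units; beyond the scatter) and it lies beyond the scatter. The value of compound 4 is a limit, not a true number, but the step shows that the group at this place on the ring matters in compounds that carry the 3-(dimethylamino)prop-1-en-1-yl group. The steps that join two limits cannot be read, and compound 4 now sits with compound 1 and compound 2 at the same edge of the assay: the limit of < 0.3 nM in this assay, at which 3 of the 4 values shown sit.

The compounds shown leave open how a fluoro, a methoxy or a plain hydrogen at this aromatic carbon would compare with methyl and chloro. They also leave open how compound 1, compound 2 and compound 4 rank among themselves, and so whether exchanging vinyl for 3-(dimethylamino)prop-1-en-1-yl changes anything when methyl occupies this carbon.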